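This account rests on a few compounds, and the source may have more. Where it says the series, first, only, none or still open, it means among the compounds named here.

Compound 1, `N#Cc1c(-c2ccc(Cl)cc2)nc(SCC(=O)Nn2c(COc3ccc(Cl)cc3Cl)nc3ccccc3c2=O)n(Cc2ccccc2)c1=O`, in a functional assay on the whole organism (strain albino) for inhibition, with Rattus norvegicus as the target, read by paw edema, with stated times of 1 h and 2 h, at a dose of 100 mg/kg by the oral route (a lower number here means less inhibition, a higher number more inhibition at the dose given (going by the name of the read-out)), gives 77.2%.
Compound 2, `N#Cc1c(-c2ccc(O)cc2)nc(SCC(=O)Nn2c(COc3ccc(Cl)cc3Cl)nc3ccccc3c2=O)n(Cc2ccccc2)c1=O`, gives 56.1%.
Compound 3, `N#Cc1c(Nc2ccccc2)nc(SCC(=O)Nn2c(COc3ccc(Cl)cc3Cl)nc3ccccc3c2=O)nc1-c1ccc(Cl)cc1`, gives 50.9%.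

Compound 1 and compound 2 differ in one place, (hydroxy in place of chloro on an aromatic carbon), and that change gives a number 21.1 percentage points lower from compound 1 to compound 2 (beyond the scatter). Compound 3 has the lowest of the three numbers; its core differs from the core of compound 1 in several ways, and the difference between the two cores is not broken down here. Compound 4, `N#Cc1c(Nc2ccccc2)nc(SCC(=O)Nn2c(COc3ccc(Cl)cc3Cl)nc3ccccc3c2=O)nc1-c1ccc(O)cc1`, carries the same change on the core of compound 3, namely (hydroxy in place of chloro on an aromatic carbon), and has yet to be measured in this assay. Within the data shown here, a step of similar direction is expected from compound 3 to compound 4, a number 17.9 percentage points lower from compound 3 to compound 4 (beyond the scatter), because a number 21.1 percentage points lower from compound 1 to compound 2 (beyond the scatter) is the only measured instance of this change. That expectation rests on a single pair on a different core, so it is held loosely. Compound 4 is therefore estimated at 33%, with a likely range from 15% to 50%.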

Compound 4, a percentage reported as inhibition, in the whole organism at one dose (the size of the read-out at that dose, not a potency): 91.2%
The estimate for compound 4 lay 58.2 percentage points below the measured number, and the stated range ends below it.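

In this assay, hydroxy in place of chloro on an aromatic carbon gave a number 40.3 percentage points higher from compound 3 to compound 4 (beyond the scatter), so the change did not carry over from one core to the other in direction or in size: the same change on two cores in this assay, a number 21.1 percentage points lower (beyond the scatter) from compound 1 to compound 2 and a number 40.3 percentage points higher (beyond the scatter) from compound 3 to compound 4, 61.4 percentage points apart, beyond the scatter of two such steps

Among these compounds, for these two pairs, then, the step from 4-chlorophenyl to 4-hydroxyphenyl depends on the core that carries it, and the step on one core gives no guide to the step on the other. This does not show which of the several differences between the two cores accounts for the reversal, and each direction rests on a single pair.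

The compounds shown leave open how an amine or a methoxy group at the same place would behave on each core.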